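The source may report more compounds than this note shows. Statements on the series, on what has been measured and on what is new or still open speak of the compounds shown alone.

Measured compounds:
Compound 1, `CN(C)CCCNc1nc(-c2ccc(NC(=O)Nc3ccccc3F)cc2)nc2ccsc12`, gives 470 nM.
Compound 2, `CN(C)CCCNc1nc(-c2ccc(NC(=O)Nc3ccc(Cl)cc3)cc2)nc2c(Cl)c(Cl)sc12`, gives 330 nM.
Compound 3, `CN(C)CCNc1nc(-c2ccc(NC(=O)Nc3ccccc3)cc2)nc2ccsc12`, gives 620 nM.

These values come from a functional assay on HT-29 cells (Homo sapiens) for cytotoxicity, read by MTT assay, with a stated time of 72 h; on this read-out higher numbers stand for weaker inhibition and lower numbers for stronger inhibition. Compound 2 shows the lowest number of the three, yet its gap to compound 1 and its gap to compound 3 both lie within the usual scatter, so no order among them can be claimed. Compound 4, `CN(C)CCCNc1nc(-c2ccc(NC(=O)Nc3ccc(Cl)cc3Cl)cc2)nc2c(Cl)c(Cl)sc12`, has not been measured. It differs from compound 2 in one place: chloro in place of hydrogen on an aromatic carbon. Within the data shown here, no measured pair shows this change, so its size is unknown from these data; a step no larger than the scatter, in either direction, is expected in this assay. Compound 4 is estimated at 280 nM, with a range from 120 nM to 650 nM. The expected step is a 1.2-fold lower number from compound 2 to compound 4 (0.07 log units; within the scatter).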

Compound 4, half-maximal inhibitory concentration: 1320 nM
Compound 4: the middle estimate sits 4.7-fold (0.67 log units) below what was measured; the measured number lies above the stated range.
By their numbers in this assay, from the lowest: compounds 2, 1 and 3 (each within the scatter of the next); then compound 4.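

In this assay, the change from 4-chlorophenyl to 2,4-dichlorophenyl gives a 4.0-fold higher number from compound 2 to compound 4 (0.60 log units; beyond the scatter) and is the first single-place step shown here. It shows that this position, ortho to a large group, does not tolerate a chloro group in place of hydrogen without a loss in this assay. The data offer no explanation for this step.

As far as these compounds go, whether methyl or methoxy at this position would produce a similar step remains open. So does whether the step would recur with a morpholine in place of the dimethylamino group.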